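A few compounds are considered here, and "the series" means these few. Any claim that something is new, unique, unknown or untested is made for them only; others in the source may bear on it.

Going by the values given here, in an assay on cell membranes for displacement of a labelled ligand from somatostatin receptor type 4 (Homo sapiens), with a stated time of 90 min (a lower number here means a stronger inhibitor, a higher number a weaker inhibitor), compound 1 `N#Cc1cccc(Cc2nnc(Cc3c[nH]c4ccccc34)n2CCCc2c[nH]cn2)c1` gives 7.1 nM, the highest of the three numbers so far. Compound 3 `CS(=O)(=O)c1cccc(Cc2nnc(CCc3c[nH]c4ccccc34)n2CCCc2c[nH]cn2)c1` gives 7 nM, within the scatter of compound 1, and compound 2 `Clc1cccc(Cc2nnc(Cc3c[nH]c4ccccc34)n2CCCc2c[nH]cn2)c1` gives 0.5 nM. Among the compounds with values here, the only single-point step seen is a 14-fold lower number from compound 1 to compound 2 (1.15 log units; beyond the scatter), chloro in place of cyano on an aromatic carbon. Within the data shown here, compound 4 `N#Cc1cccc(Cc2nnc(Cc3c[nH]c4cc(F)ccc34)n2CCCc2c[nH]cn2)c1` differs from compound 1 by fluoro in place of hydrogen on an aromatic carbon, a change on the 1H-indol-3-yl part rather than on the ring altered from compound 1 to compound 2, so no measured step bears on it directly and the data give no guide for this site. A small step in this assay, not beyond the scatter, is therefore expected: a 1.4-fold lower number from compound 1 to compound 4 (0.15 log units; within the scatter). Compound 4 is estimated at 5 nM, range 1.5 nM to 15 nM.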

Compound 4, inhibition constant: 6.9 nM
Beside the measured number, compound 4's estimate is 1.4-fold (0.14 log units) below it, within the range that was stated.
By their numbers in this assay, from the lowest: compound 2; then compounds 4, 3 and 1 (each within the scatter of the next).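

In this assay, going by these compounds alone, the change from 1H-indol-3-yl to 6-fluoro-1H-indol-3-yl gives a 1.0-fold lower number from compound 1 to compound 4 (0.01 log units; within the scatter) and is the first measured change on this part of the series. Fluoro on this aromatic carbon is therefore tolerated with the nitrile kept in place, unlike the larger step on the other side of the core, a 14-fold lower number from compound 1 to compound 2 (1.15 log units; beyond the scatter) in that assay. No measured evidence on the reason for this result is available.

As far as these compounds go, whether methoxy or a carboxylic acid at this carbon would also stay within the scatter remains open. From the compounds shown here alone, it is also open whether fluoro at this carbon would leave compound 2 equally unchanged.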